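From 3-nitrophenyl to 4-chlorophenyl: an expected small step

This account rests on a few compounds, and the source may have more. Where it says the series, first, only, none or still open, it means among the compounds named here.

Of the compounds shown here, three built on a shared core have been measured so far in a functional assay on NCI/ADR cells (Homo sapiens) for cytotoxicity, read by sulforhodamine B assay; on this read-out higher numbers stand for weaker inhibition of growth and lower numbers for stronger inhibition of growth. Compound 1 `CC1=CC[C@@H]([C@@](C)(O)CCCC(C)(C)NC(=S)N/N=C\c2ccccc2)CC1` serves as the reference, as its ring carries no added group (6970 nM). Compound 3 `CC1=CC[C@@H]([C@@](C)(O)CCCC(C)(C)NC(=S)N/N=C\c2cccc([N+](=O)[O-])c2)CC1` stands level with it at the low end of the three (6720 nM), while compound 2 `CC1=CC[C@@H]([C@@](C)(O)CCCC(C)(C)NC(=S)N/N=C\c2ccc(N(C)C)cc2)CC1` stands clearly higher (25200 nM).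

The next candidate is compound 4 `CC1=CC[C@@H]([C@@](C)(O)CCCC(C)(C)NC(=S)N/N=C\c2ccc(Cl)cc2)CC1`, which has 4-chlorophenyl in place of 3-nitrophenyl on a carbon with a double bond to nitrogen. Among the compounds with values here, no measured pair makes this exact swap, and no measured compound carries chlorine, so the evidence is indirect. Adding nitro left the number within the ordinary scatter of repeat measurements (a 1.0-fold lower number from compound 1 to compound 3 (0.02 log units; within the scatter)). Adding dimethylamino gave a modest rise (a 3.6-fold higher number from compound 1 to compound 2 (0.56 log units; beyond the scatter)), and replacing that ring with 3-nitrophenyl gave a drop of similar size (a 3.8-fold lower number from compound 2 to compound 3 (0.57 log units; beyond the scatter)). Both steps beyond the scatter involve compound 2, while compound 1 and compound 3 agree.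

On that thin basis, no step beyond the scatter is expected in this assay (a 1.1-fold lower number from compound 3 to compound 4 (0.05 log units; within the scatter)). The estimate for compound 4 is 6000 nM (expected range 3000 nM to 13000 nM).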

Compound 4, concentration for 50% growth inhibition: 7580 nM
Beside the measured number, compound 4's estimate is 1.3-fold (0.10 log units) below it; measured number inside the range.
By their numbers in this assay, from the lowest: compounds 3, 1 and 4 (each within the scatter of the next); then compound 2.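

In this assay, chloro in place of hydrogen on the ring is a third substitution that leaves the number within the scatter (a 1.1-fold higher number from compound 1 to compound 4 (0.04 log units; within the scatter)), and swapping the whole ring of compound 3 for 4-chlorophenyl also stays within it (a 1.1-fold higher number from compound 3 to compound 4 (0.05 log units; within the scatter)); on this carbon with a double bond to nitrogen, then, the aromatic ring can carry two quite different groups, in two differently numbered places, with no readable change. Compound 2 now stands apart from three compounds rather than two, as chloro in place of dimethylamino gives a step beyond the scatter (a 3.3-fold lower number from compound 2 to compound 4 (0.52 log units; beyond the scatter)), so among these four, the dimethylamino compound alone departs from the rest. Nothing available here accounts for that difference or for the lack of one among the other three.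

The four compounds leave open whether moving a group around the ring matters, since 4-nitrophenyl and 3-chlorophenyl do not appear among them. They also leave open whether a methoxy group, a hydroxyl or a carboxylic acid on the ring would fall with compound 2 or with the other three.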